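A few compounds are considered here, and "the series" means these few. Any claim that something is new, unique, unknown or untested is made for them only; others in the source may bear on it.

Measured so far in a functional assay on HT-29 cells (Homo sapiens) for inhibition, read by luminescence and CellTiter-Glo, with a stated time of 12 h; a lower number here means that less compound is needed, a higher number that more compound is needed for the effect:
- compound 1, `COc1cccc(NC(=O)Nc2cc(Oc3ccc4nc(NC(=O)C5CC5)sc4c3)ccc2F)c1`: 1370 nM
- compound 2, `O=C(Nc1nc2ccc(Oc3ccc(F)c(NCc4cccc(C(F)(F)F)c4)c3)cc2s1)C1CC1`: > 20000 nM

Compound 2 carries a 3-(trifluoromethyl)benzyl group on a nitrogen on an aromatic ring. In this assay compound 2 reaches only a limit, > 20000 nM, so no number is known for it. Compound 1 differs from it in one place and in this assay compound 1 gives 1370 nM. The step of an at least 14-fold higher number from compound 1 to compound 2 (1.16 log units; beyond the scatter) can only be stated as a lower bound, because of the limit of > 20000 nM in this assay, at which 1 of the 2 values shown sits.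

Compound 3, `CC(=O)c1cccc(NC(=O)Nc2cc(Oc3ccc4nc(NC(=O)C5CC5)sc4c3)ccc2F)c1`, is reached from compound 2 by the change ((3-acetylphenyl)carbamoyl in place of 3-(trifluoromethyl)benzyl on a nitrogen on an aromatic ring). Among the measured compounds shown here, this undoes the one change that separated compound 1 from compound 2, leaving an acetyl group where compound 1 has a methoxy group. For the measured compounds named here, the only measured step that bears on it is an at least 14-fold higher number from compound 1 to compound 2 (1.16 log units; beyond the scatter), which was large; run in the reverse direction it points to a large step towards a lower number, and the close kinship to compound 1 suggests compound 3 should land near the value of compound 1. The step of an at least 13-fold lower number from compound 2 to compound 3 (1.12 log units; beyond the scatter) is therefore the expected size. Compound 3 is estimated at 1500 nM, within 500 nM to 5000 nM.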

Compound 3, half-maximal effective concentration: 1000 nM
Beside the measured number, compound 3's estimate is 1.5-fold (0.18 log units) above it, and the stated range covers the measured number.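

On a nitrogen on an aromatic ring, (3-acetylphenyl)carbamoyl in place of 3-(trifluoromethyl)benzyl gives an at least 20-fold lower number from compound 2 to compound 3 (1.30 log units; beyond the scatter) in this assay, so a second carbamoyl compound now stands on the same side of this large gap as compound 1. The size of that step can be given only as a lower bound because compound 2 sits at a limit of the assay: the limit of > 20000 nM in this assay, at which 1 of the 3 values shown sits. Acetyl in place of methoxy on an aromatic carbon gives a 1.4-fold lower number from compound 1 to compound 3 (0.14 log units; within the scatter), so the two carbamoyl compounds are not separated in this assay, and the effect seen for compound 1 does not depend on keeping the methoxy group.

The exchange between compound 2 and compound 3 alters the link to the outer ring and the group on that ring together, which leaves open how much of the step belongs to the carbamoyl link itself. On these data alone, whether the tolerance seen for acetyl and methoxy extends to a primary amine or a carboxylic acid on that aromatic carbon also remains open.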